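A few compounds are considered here, and "the series" means these few. Any claim that something is new, unique, unknown or untested is made for them only; others in the source may bear on it.

Compound 1 `CCC(C)C(NC(=O)n1nnc2ccccc21)C(=O)NC1CCCCC1` gives 98000 nM in a functional assay on MOLT-4 cells (Homo sapiens) for inhibition; on this read-out lower numbers stand for stronger inhibition and higher numbers for weaker inhibition.
Compound 3 `CCC(C)C(NC(=O)n1nnc2ccccc21)C(=O)NC1CCCC1` gives 94000 nM in this assay.
Compound 2 `CC(C)C(NC(=O)n1nnc2ccccc21)C(=O)NC1CCCC1` reaches only a limit of this assay, at > 200000 nM.

Compound 2 therefore stands at the top edge of what has been observed in this assay: the limit of > 200000 nM in this assay, at which 1 of the 3 values shown sits. It does not carry a proper number, only the sign that the true value lies at or beyond that edge.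

The step to compound 4 `CC(C)C(NC(=O)n1nnc2ccccc21)C(=O)NC1CCCCC1` is a single swap of the ring on the amide nitrogen: cyclohexyl in place of cyclopentyl on an amide-type nitrogen. Going by the values given here, the carbonyl carbon is the only other neighbour of that nitrogen, so nothing else in the molecule moves.

Among the compounds with values here, one measured step bears directly on this swap, in the reverse direction and on the pair with the methyl added on the chain: a 1.0-fold lower number from compound 1 to compound 3 (0.02 log units; within the scatter). That exchange left the number unchanged within the scatter. Within the data shown here, no other pair speaks to the ring size.

Compound 4 is therefore expected to show no step beyond the scatter from compound 2, a step that the limit leaves unreadable from compound 2 to compound 4, because the same exchange on the neighbouring pair gave a 1.0-fold lower number from compound 1 to compound 3 (0.02 log units; within the scatter). Since compound 2 sits at a limit, compound 4 is most likely to come back as a limit as well. The estimate for compound 4 in this assay is 250000 nM, with a range from 100000 nM to 600000 nM.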

Compound 4, half-maximal inhibitory concentration: 97000 nM
Estimate against measurement, compound 4: 2.6-fold (0.41 log units) above, and the stated range ends above it.
By their numbers in this assay, from the lowest: compounds 3, 4 and 1 (each within the scatter of the next). At a limit, above all of these: compound 2.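

In this assay, the swap of cyclopentyl for cyclohexyl on the amide-type nitrogen now turns out not to be silent on every core: an at least 2.0-fold lower number from compound 2 to compound 4 (0.31 log units; beyond the scatter), whereas the same exchange had left compound 1 and compound 3 within the scatter of each other. Putting hydrogen in place of the methyl on the saturated chain carbon gives a 1.0-fold lower number from compound 1 to compound 4 (0.00 log units; within the scatter), so with cyclohexyl on the nitrogen this change shows no readable effect, although with cyclopentyl it did: the same change on two cores in this assay, an at least 2.1-fold lower number (0.32 log units; beyond the scatter) from compound 2 to compound 3 and a 1.0-fold higher number (0.00 log units; within the scatter) from compound 4 to compound 1; the limit leaves it open whether they differ Compound 2 alone stands apart from the other three compounds, and its > 200000 nM is a limit of the assay, not a number.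

How far compound 2 truly lies from the others stays unknown, and with it whether the ring swap really behaves differently on the two cores: the same change on two cores in this assay, a 1.0-fold lower number (0.02 log units; within the scatter) from compound 1 to compound 3 and an at least 2.0-fold higher number (0.31 log units; beyond the scatter) from compound 4 to compound 2; the limit leaves it open whether they differ The compounds shown also leave open what a cycloheptyl ring or an open hexyl chain on the amide-type nitrogen would do, and what a longer chain or a carboxylic acid would do in place of the chain methyl.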